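Ortho-substituted biaryl amides: from fluorophenyl to dimethoxyphenyl

A few compounds are considered here, and "the series" means these few. Any claim that something is new, unique, unknown or untested is made for them only; others in the source may bear on it.

Compound 1 `COc1cc2c(Oc3ccc(NC(=O)c4cc(-c5ccccc5)ccn4)cc3F)ccnc2cc1OCCCN1CCN(C)CC1` gives 82 nM in a functional assay on HT-29 cells (Homo sapiens) for cytotoxicity, read by MTT assay, with a stated time of 72 h; on this read-out higher numbers stand for weaker inhibition and lower numbers for stronger inhibition. For the measured compounds named here, compound 2 `COc1cc2c(Oc3ccc(NC(=O)c4cc(-c5ccccc5F)ccn4)cc3F)ccnc2cc1OCCCN1CCN(C)CC1` gives 220 nM in this assay, the higher of the two numbers measured so far; the step of a 2.7-fold higher number from compound 1 to compound 2 (0.43 log units; beyond the scatter) is the only comparison available, and it came with fluoro in place of hydrogen on an aromatic carbon. Compound 3 `COc1ccc(-c2ccnc(C(=O)Nc3ccc(Oc4ccnc5cc(OCCCN6CCN(C)CC6)c(OC)cc45)c(F)c3)c2)c(OC)c1` has not been measured. It differs from compound 2 in that (2,4-dimethoxyphenyl in place of 2-fluorophenyl on an aromatic carbon). Going by the values given here, no measured step covers this change: the one known step concerns fluorine against hydrogen at the same aromatic carbon, not methoxy groups, so it offers only a loose guide. The expected step of a 1.1-fold higher number from compound 2 to compound 3 (0.06 log units; within the scatter) is therefore set close to none beyond the scatter, with wide uncertainty in either direction. Compound 3 is estimated at 250 nM in this assay, within a range of 60 nM to 1000 nM.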

Compound 3, half-maximal inhibitory concentration: 420 nM
The estimate for compound 3 lay 1.7-fold (0.23 log units) below the measured number, within the range that was stated.
By their numbers in this assay, from the lowest: compound 1; then compounds 2 and 3 (each within the scatter of the next).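

Swapping 2-fluorophenyl for 2,4-dimethoxyphenyl on this aromatic carbon, opposite the ring nitrogen, stays within the scatter in this assay (a 1.9-fold higher number from compound 2 to compound 3 (0.28 log units; within the scatter)), so these two substituted phenyl groups are not separated by this read-out. Against the plain phenyl group, the same 2,4-dimethoxyphenyl group gives a step beyond the scatter (a 5.1-fold higher number from compound 1 to compound 3 (0.71 log units; beyond the scatter)), which leaves compound 1 with the lowest number of the three and shows that both substituted phenyl groups read higher than phenyl. No measurement shown here bears on the reason for these steps.

The compounds shown leave open which of the two methoxy groups accounts for the step from phenyl, as a phenyl group carrying only one methoxy group would be needed to separate them. From the compounds shown here alone, how a phenyl group bearing an amine or a carboxylic acid at this position would read also remains open.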